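A few compounds are considered here, and "the series" means these few. Any claim that something is new, unique, unknown or untested is made for them only; others in the source may bear on it.

Measured in a functional assay on SK-BR-3 cells (Homo sapiens) for antiproliferative activity, read by MTT assay, with a stated time of 72 h; on this read-out higher numbers stand for weaker inhibition and lower numbers for stronger inhibition:
Compound 1 `C=C(C)CCOC(=O)C[C@@H]1C(C(=O)OC)=CO[C@@H](O[C@@H]2O[C@H](COC(C)=O)[C@@H](OC(C)=O)[C@H](OC(C)=O)[C@H]2OC(C)=O)/C1=C/C`: > 15000 nM, a limit.
Compound 2 `C/C=C1/[C@H](O[C@@H]2O[C@H](CO)[C@@H](O)[C@H](O)[C@H]2O)OC=C(C(=O)OC)[C@H]1CC(=O)OCCCCCCCCCCCCCCC`: 1600 nM.
Compound 3 `C/C=C1/[C@H](O[C@@H]2O[C@H](COC(C)=O)[C@@H](OC(C)=O)[C@H](OC(C)=O)[C@H]2OC(C)=O)OC=C(C(=O)OC)[C@H]1CC(=O)SCCC`: > 15000 nM, a limit.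

Among the measured compounds shown here, compound 2 is the only compound here with a true number. The other two read-outs are the limit of > 15000 nM in this assay, at which 2 of the 3 values shown sit.

Compound 4 `C/C=C1/[C@H](O[C@@H]2O[C@H](CO)[C@@H](O)[C@H](O)[C@H]2O)OC=C(C(=O)OC)[C@H]1CC(=O)OCCC` follows from compound 2 through hydrogen in place of dodecyl on a saturated chain carbon, three bonds along the chain from an oxygen next to a carbonyl group.

For the measured compounds named here, the single measured step, a step that the two limits leave unreadable from compound 1 to compound 3, gives no size to carry over. Going by the values given here, the only guide is weak: compound 3, with its propylsulfanyl group, gives > 15000 nM, a limit.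

Weaker inhibition in this assay is therefore expected, with an estimated 6.3-fold higher number from compound 2 to compound 4 (0.80 log units; beyond the scatter).

For compound 4 the estimate is 10000 nM, with an expected range of 3500 nM to 30000 nM.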

Compound 4, half-maximal inhibitory concentration: > 15000 nM
Compound 4 gave a limit, no number; the forecaster's own chance of this, stated with the estimate: 55%; middle value at least 1.5-fold (0.17 log units) from the limit.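

In this assay, among the compounds shown here, this is the first step with a readable size: hydrogen in place of dodecyl on a saturated chain carbon gives an at least 9.3-fold higher number from compound 2 to compound 4 (0.97 log units; beyond the scatter). The step between compound 1 and compound 3 cannot be read, so this position is the only one shown where a change registers, and dodecyl is needed here to keep compound 2 off the limit. Compound 4 sits at that limit, and its value is not a number: the limit of > 15000 nM in this assay, at which 3 of the 4 values shown sit.

As far as these compounds go, how much chain between compound 4 and compound 2 is required remains open. So does whether a longer chain, an amine or a carboxylic acid in place of dodecyl would keep a measurable value.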